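A few compounds are considered here, and "the series" means these few. Any claim that something is new, unique, unknown or untested is made for them only; others in the source may bear on it.

In a functional assay on A549 cells (Homo sapiens) for inhibition, read by sulforhodamine B assay, with a stated time of 48 h (on this read-out higher numbers stand for weaker inhibition of growth and lower numbers for stronger inhibition of growth), compound 1 `COc1cc(-c2nn(-c3cccc(NC(=O)c4cccc(C(F)(F)F)c4)c3)cc2-c2ccncc2)ccc1Cl` gives 1870 nM. Compound 2 `O=C(Nc1cccc(-n2cc(-c3ccncc3)c(-c3ccc(Cl)c(O)c3)n2)c1)Nc1cc(C(F)(F)F)cc(C(F)(F)F)c1` gives 298 nM, which leaves compound 1 with the higher of the two numbers and so the weaker inhibition of growth, by a gap beyond the usual scatter. The two compounds differ in more than one place, so this gap cannot be tied to any single structural feature.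

The next compound, compound 3 `COc1cc(-c2nn(-c3cccc(NC(=O)Nc4ccc(Cl)c(C(F)(F)F)c4)c3)cc2-c2ccncc2)ccc1Cl`, keeps the core of compound 1 and changes one group on the carbonyl carbon: (4-chloro-3-(trifluoromethyl)phenyl)amino stands in place of 3-(trifluoromethyl)phenyl ((4-chloro-3-(trifluoromethyl)phenyl)amino in place of 3-(trifluoromethyl)phenyl on a carbonyl carbon). For the measured compounds named here, no measured pair isolates this change, so any forecast in this assay is loose. Going by the values given here, the only guide is that the number of compound 2, at 298 nM, shows that values well under that of compound 1 occur in this small set. A moderate move toward stronger inhibition therefore seems more likely than no change, and the expected step is a 3.4-fold lower number from compound 1 to compound 3 (0.53 log units; beyond the scatter). For compound 3 the estimated value is 550 nM, with an expected range of 180 nM to 1700 nM.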

Compound 3, concentration for 50% growth inhibition: 1020 nM
Estimate against measurement, compound 3: 1.9-fold (0.27 log units) below; measured number inside the range.
By their numbers in this assay, from the lowest: compound 2; then compounds 3 and 1 (each within the scatter of the next).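

In this assay, for the compounds shown here, the first single-place comparison in this set is a 1.8-fold lower number from compound 1 to compound 3 (0.26 log units; within the scatter), with (4-chloro-3-(trifluoromethyl)phenyl)amino in place of 3-(trifluoromethyl)phenyl on a carbonyl carbon. The position on this carbonyl carbon therefore tolerates the entering group, with its extra nitrogen, its chlorine and its hydrogen-bond donor, without a difference that can be told from repeated measurement, at least for this one pair on the core of compound 1. Nothing available explains this result or links it to any property of the two groups.

Because the nitrogen and the chlorine enter together in this one step, the pair cannot show what each would do alone, and (3-(trifluoromethyl)phenyl)amino on the same carbonyl carbon would separate the two. As far as these compounds go, it also remains open whether this tolerance extends to quite different groups at this place, such as a morpholine, a carboxylic acid or a longer alkyl chain, or whether it would hold on a core carrying other substituents.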